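The source may report more compounds than this note shows. Statements on the series, on what has been measured and on what is new or still open speak of the compounds shown alone.

Measured so far:
compound 1, `C=CCOc1ccccc1C1CC(=O)c2ccccc2O1`, a functional assay on RAW264.7 cells (Mus musculus) for inhibition, read by Griess assay, with stated times of 1 h and 24 h; a lower number here means a stronger inhibitor, a higher number a weaker inhibitor: 37800 nM
compound 2, `CC(C)=CCOc1ccccc1C1CC(=O)c2ccccc2O1`, this assay: 32700 nM

Compound 2 holds the lowest of the two numbers, but only by a 1.2-fold lower number from compound 1 to compound 2 (0.06 log units; within the scatter), so the two cannot be set in order. That single step is the only one measured at the saturated chain carbon bound to an oxygen on the aromatic ring, and it shows that swapping one unsaturated substituent for a larger one there leaves this assay unchanged beyond the scatter.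

Compound 3, `COCOc1ccccc1C1CC(=O)c2ccccc2O1`, is not yet measured. It differs from compound 2 by methoxy in place of 2-methylprop-1-en-1-yl on a saturated chain carbon bound to an oxygen on an aromatic ring. For the measured compounds named here, the change sits at the same position as the one step known, but it trades a hydrocarbon group for an oxygen-containing one; nothing measured covers that. With only the flat step from compound 1 to compound 2 as a guide, no shift beyond the scatter is expected, and compound 3 is estimated at 38000 nM, with a range of 14000 nM to 100000 nM, meaning a step of a 1.2-fold higher number from compound 2 to compound 3 (0.07 log units; within the scatter).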

Compound 3, half-maximal inhibitory concentration: 32600 nM
Compound 3: middle estimate off by 1.2-fold (0.07 log units), on the high side, and the stated range covers the measured number.
By their numbers in this assay, from the lowest: compounds 3, 2 and 1 (each within the scatter of the next).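

In this assay, the step with methoxy in place of 2-methylprop-1-en-1-yl on a saturated chain carbon bound to an oxygen on an aromatic ring is a 1.0-fold lower number from compound 2 to compound 3 (0.00 log units; within the scatter), and the step with methoxy in place of vinyl is a 1.2-fold lower number from compound 1 to compound 3 (0.06 log units; within the scatter). The flat picture at this position therefore now extends beyond hydrocarbon groups: an entering group with a hydrogen-bond acceptor and no double bond outside aromatic rings gives no shift beyond the scatter, and compounds 1, 2 and 3 stay level. No supporting evidence bears on why this position stays flat.

On these data alone, whether any group here can move the number beyond the scatter stays open, for instance an amine, a carboxylic acid or a longer chain. The compounds shown also leave open how changes elsewhere on the shared core would read.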